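From Acetamide to Benzamide on a Shared Core

The compounds below may be only part of what the source reports. "The series", "measured", "known", "first", "only" and "open" are said of these compounds alone.

Compound 1 `CC(=O)Nc1cc(NC(=O)Nc2ccc3c(c2)OCCO3)ccc1C` and compound 2 `CC(=O)Nc1cc(NC(=O)c2ccc3c(c2)OCCO3)ccc1C` share a core and have both been tested in a functional assay on A375P cells (Homo sapiens) for antiproliferative activity; a higher number here means a weaker inhibitor, a lower number a stronger inhibitor. Compound 1 returns > 30000 nM there, which is a limit of the assay rather than a number (the limit of > 30000 nM in this assay, at which 1 of the 2 values shown sits). For the measured compounds named here, compound 2 gives 12900 nM in this assay, and that is the only number among the values at hand, so compound 2 stands as the sole measured reference point. Going by the values given here, no pair of measured compounds differs in a single place, so no measured step is available to guide the next move.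

Compound 3 `Cc1ccc(NC(=O)c2ccc3c(c2)OCCO3)cc1NC(=O)c1ccccc1` is the compound still to be measured. It differs from compound 2 in one place: phenyl in place of methyl on a carbonyl carbon. Read one bond further out, the same change is acetyl to benzoyl, or acetamido to benzamido. Among the compounds with values here, with no measured step to lean on, a modest gain seems the more likely outcome, though a result within the usual scatter cannot be excluded. Compound 3 is therefore expected to sit near 5000 nM, within a range from 1000 nM to 30000 nM. The step expected is a 2.6-fold lower number from compound 2 to compound 3 (0.41 log units; beyond the scatter).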

Compound 3, half-maximal inhibitory concentration: > 30000 nM
Compound 3 gave a limit, no number (the forecaster's own chance of this, stated with the estimate: 25%); at least 6.0-fold (0.77 log units) between middle value and limit.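

On this carbonyl carbon, phenyl in place of methyl gives an at least 2.3-fold higher number from compound 2 to compound 3 (0.36 log units; beyond the scatter) in this assay, so this first measured step on the shared core runs toward weaker activity, not toward a gain. Acetamido is therefore the better of the two groups tested here, and benzamido gives no measurable inhibition within the range of this assay. Compound 3 reads > 30000 nM, which is a limit and not a number, so the full size of the loss cannot be read, and compound 2 remains the only compound with a measured value, with the others held at the same ceiling: the limit of > 30000 nM in this assay, at which 2 of the 3 values shown sit.

As far as these compounds go, whether the loss belongs to the aromatic ring itself or would follow from any group larger than methyl stays open, and an ethyl group or a cyclohexyl ring on this carbonyl carbon would bear on that question. Also open, from the compounds shown here alone, is whether an amine or a carboxylic acid carried on the entering phenyl would bring the value back within the measurable range of this assay.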